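The compounds below may be only part of what the source reports. "The series", "measured", "known", "first", "only" and "open" are said of these compounds alone.

Measured in a functional assay on RAW264.7 cells (Mus musculus), read by fluorescence; on this read-out lower numbers stand for stronger inhibition and higher numbers for weaker inhibition:
- Compound 1 `CCOC(=O)C1=CCCCC1S(=O)(=O)Cc1ccc(F)cc1Cl`: 10 nM; 10000 nM; 5.7 nM (3 entries)
- Compound 2 `COC(=O)C1=CCCCC1S(=O)(=O)Cc1ccc(F)cc1Cl`: 99 nM
- Compound 3 `O=S(=O)(Cc1ccc(F)cc1Cl)C1CCCC=C1CO`: > 10000 nM (a limit)

Compound 3 stands at a limit of this assay, with > 10000 nM, so it gives no exact starting point. Compound 4 `CCC(=O)C1=CCCCC1S(=O)(=O)Cc1ccc(F)cc1Cl` has propanoyl in place of hydroxymethyl on a double-bonded ring carbon. The closest measured step is an at least 100-fold higher number from compound 2 to compound 3 (2.00 log units; beyond the scatter), a large one, which replaced methoxycarbonyl with hydroxymethyl at that same place. Compound 1 is a looser guide, with entries of the several entries of compound 1 in this assay, 10 nM; 10000 nM; 5.7 nM (3 entries). Read in reverse, the step to compound 3 points to a large move towards stronger inhibition. The expected change is an at least 66-fold lower number from compound 3 to compound 4 (1.82 log units; beyond the scatter). Compound 4 is estimated at 150 nM, with an expected range of 15 nM to 3000 nM.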

Compound 4, half-maximal inhibitory concentration: 64 nM
For compound 4 the middle estimate is 2.3-fold (0.37 log units) above the measured one; measured number inside the range.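

In this assay, an at least 150-fold lower number from compound 3 to compound 4 (2.19 log units; beyond the scatter), so at this double-bonded ring carbon a propanoyl group restores inhibition that hydroxymethyl does not give. Compound 3 gives > 10000 nM, which is a limit of the assay. Ethyl in place of methoxy on the carbonyl carbon gives a 1.5-fold lower number from compound 2 to compound 4 (0.19 log units; within the scatter), so the ester oxygen is not required for this level of inhibition.

As far as these compounds go, whether any carbonyl group suffices stays open, as does the outcome with an amide, a carboxylic acid or a chain longer than propanoyl at this place. Compound 1 offers no firm comparison with the propanoyl group: the several entries of compound 1 in this assay, 10 nM; 10000 nM; 5.7 nM (3 entries)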